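Cytotoxicity notes: from compound 2 to compound 3

The source may hold more compounds than are shown below. What is called first, only, known or untested is meant among the compounds shown, and "the series" means these compounds.

Compound 2 `Cc1ccc2[nH]c(=O)c(CN(Cc3ccc(C(C)(C)C)cc3)Cc3ccc(N(C)C)c(Cl)c3)cc2c1` stands at a limit in a toxicity assay on MDCK cells (Canis lupus familiaris) for cytotoxicity, read by crystal violet staining, with a stated time of 48 h; a lower number here means that less compound is tolerated, a higher number that more compound is tolerated: compound 2 gives > 10000 nM, which is a limit of the assay and not a number. Compound 1 `Cc1ccc2[nH]c(=O)c(CN(Cc3ccc(N(C)C)cc3)Cc3ccc(C(C)(C)C)cc3)cc2c1` likewise reaches only a limit in this assay, where compound 1 gives > 5000 nM. Within the data shown here, the single step between the two, a step that the two limits leave unreadable from compound 1 to compound 2, cannot be sized; the two limits concerned are those of the limit of > 10000 nM in this assay, at which 1 of the 2 values shown sits, and (the limit of > 5000 nM in this assay, at which 1 of the 2 values shown sits).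

The change to compound 3 `COc1ccc(C(C)N(Cc2ccc(C(C)(C)C)cc2)Cc2cc3cc(C)ccc3[nH]c2=O)cc1Cl` is 1-(3-chloro-4-methoxyphenyl)ethyl in place of 3-chloro-4-(dimethylamino)benzyl on an amine nitrogen. Among the measured compounds shown here, no measured step bears on it: the only step is unreadable, and neither measured compound yields a number from which a shift could be taken. Both measured compounds are tolerated up to their limits in this assay. For compound 3 no step beyond the scatter is expected, and the step is estimated as a step that the limit leaves unreadable from compound 2 to compound 3. Compound 3 is accordingly expected at 15000 nM, with a range of 5000 nM to 50000 nM, and most probably this assay will again report only a limit for compound 3.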

Compound 3, half-maximal cytotoxic concentration: > 10000 nM
Compound 3 was reported as a limit; the forecaster's own chance of this, stated with the estimate: 70%; the middle value does not contradict the limit.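

In this assay compound 3 gives > 10000 nM, which is a limit of the assay and not a number. Neither the step from compound 1 to compound 3 nor that from compound 2 to compound 3 can be read. The compounds shown leave open at what concentration compound 1, compound 2 or compound 3 reaches its half-maximal cytotoxic concentration, and whether these exchanges change tolerance at all.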